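Amide-Side Chain Lengthening in a Tetrazole Secretagogue Series

The compounds below may be only part of what the source reports. "The series", "measured", "known", "first", "only" and "open" are said of these compounds alone.

Measured compounds:
compound 1 `CCCCNC(=O)CCn1nnnc1[C@@H](COCc1ccccc1)NC(=O)C(C)(C)N` gives 2190 nM in an assay on isolated protein for displacement of a labelled ligand from growth hormone secretagogue receptor type 1 (Homo sapiens), with a stated time of 1 h; on this read-out higher numbers stand for weaker inhibition and lower numbers for stronger inhibition
compound 2 `CC(C)(N)C(=O)N[C@H](COCc1ccccc1)c1nnnn1CCC(=O)NCc1ccccc1` gives 1070 nM in this assay

Within the data shown here, compound 2 is the lower of the two numbers; the one step, a 2.0-fold lower number from compound 1 to compound 2 (0.31 log units; beyond the scatter), came from putting an aromatic ring onto that chain. Compound 3 `CC(C)(N)C(=O)N[C@H](COCc1ccccc1)c1nnnn1CCC(=O)NCCCc1ccccc1` changes the same position again: phenethyl in place of phenyl on a saturated chain carbon bound to an amide-type nitrogen. Among the measured compounds shown here, no measured pair tests moving the ring outward, so the single step bears only loosely on it. A step within the scatter is therefore expected, a 1.1-fold higher number from compound 2 to compound 3 (0.05 log units; within the scatter), and for compound 3 the estimate is 1200 nM with a range from 500 nM to 3000 nM.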

Compound 3, inhibition constant: 820 nM
Compound 3: middle estimate off by 1.5-fold (0.17 log units), on the high side; the measured number falls inside the stated range.
By their numbers in this assay, from the lowest: compounds 3 and 2 (each within the scatter of the next); then compound 1.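

Changing benzylcarbamoyl to (3-phenylpropyl)carbamoyl gives a 1.3-fold lower number from compound 2 to compound 3 (0.12 log units; within the scatter), so in this assay this position tolerates the longer link but shows no gain from it. With phenyl in place of methyl on a saturated chain carbon, three bonds along the chain from an amide-type nitrogen, the comparison gives a 2.7-fold lower number from compound 1 to compound 3 (0.43 log units; beyond the scatter), so the separation from compound 1 also holds with the ring further out. No measured evidence on the origin of either step is available.

Open, going by these compounds, is whether a chain longer than 3-phenylpropyl, or an amine or carboxylic acid on the phenyl ring, would move the number beyond the scatter.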